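A few compounds are considered here, and "the series" means these few. Any claim that something is new, unique, unknown or untested is made for them only; others in the source may bear on it.

Measured so far:
- compound 1 `O=C1CNC(=O)N1C[C@H]1CN(c2ccc(-n3cc(-c4ccccn4)cn3)c(F)c2)C(=O)O1`: > 400 ug/mL
- compound 2 `O=C(NC[C@H]1CN(c2ccc(-n3cc(-c4ccccn4)cn3)c(F)c2)C(=O)O1)C(F)F`: > 400 ug/mL

In an ADME assay on L02 cells (Homo sapiens) for cytotoxicity, read by MTT assay, with a stated time of 48 h (on this read-out higher numbers stand for weaker inhibition and lower numbers for stronger inhibition), compound 1 gives > 400 ug/mL, which is a limit of the assay rather than a number. In this assay compound 2 gives > 400 ug/mL, also a limit. Both values sit at the limit of > 400 ug/mL in this assay, at which 2 of the 2 values shown sit, so a step that the two limits leave unreadable from compound 1 to compound 2 cannot be read. Compound 3 `CONC(=O)[C@H]1CN(c2ccc(-n3cc(-c4ccccn4)cn3)c(F)c2)C(=O)O1` differs from compound 2 by methoxycarbamoyl in place of (((difluoromethyl)carbonyl)amino)methyl on a saturated ring carbon. Within the data shown here, the only measured step, from compound 1 to compound 2, gives no readable size, so no change beyond the scatter is expected for a number no higher from compound 2 to compound 3 (the limit leaves the size open). Compound 3 is therefore estimated at 400 ug/mL, with a range from 200 ug/mL to 800 ug/mL.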

Compound 3, half-maximal inhibitory concentration: > 400 ug/mL
Compound 3 was reported as a limit; the forecaster's own chance of this, stated with the estimate: 85%; the middle value sits exactly at the limit.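

Among these compounds, no step among compound 1, compound 2 and compound 3 can be read, since each result is a limit and not a number: the limit of > 400 ug/mL in this assay, at which 3 of the 3 values shown sit. In this assay the compounds shown leave open whether these three differ at all.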